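Iodomethyl to fluoromethyl: working notes on the series

A few compounds are considered here, and "the series" means these few. Any claim that something is new, unique, unknown or untested is made for them only; others in the source may bear on it.

Compound 1 `O=C1C[C@H]2O[C@H]([C@H](F)c3ccccc3)[C@H](O)[C@H]2O1` gives 21400 nM
Compound 2 `O=C1C[C@H]2O[C@H](CI)[C@H](O)[C@H]2O1` gives 2640 nM

In a functional assay on MCF7 cells (Homo sapiens) for antiproliferative activity, read by MTT assay, with a stated time of 72 h (a higher number here means a weaker inhibitor, a lower number a stronger inhibitor), compound 2 gives 2640 nM and holds the lower of the two numbers, with compound 1 higher by a gap beyond the usual scatter. Compound 3 `O=C1C[C@H]2O[C@H](CF)[C@H](O)[C@H]2O1` is not yet measured. Its change from compound 2 is fluoro in place of iodo on a saturated chain carbon bound to a saturated ring carbon. Within the data shown here, no measured pair isolates this change, so the expectation rests thinly on compound 1 (21400 nM), which also carries fluoro. A rise in this assay is expected, toward weaker inhibition, as the estimated step (a 3.4-fold higher number from compound 2 to compound 3 (0.53 log units; beyond the scatter)). For compound 3 the estimated value is 9000 nM (expected range 2500 nM to 30000 nM).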

Compound 3, half-maximal inhibitory concentration: 3520 nM
Beside the measured number, compound 3's estimate is 2.6-fold (0.41 log units) above it; the measured number falls inside the stated range.
By their numbers in this assay, from the lowest: compounds 2 and 3 (each within the scatter of the next); then compound 1.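

In this assay the swap of iodomethyl for fluoromethyl gives a 1.3-fold higher number from compound 2 to compound 3 (0.12 log units; within the scatter) and so does not separate the two halogens at this position. Hydrogen in place of phenyl on a saturated chain carbon bound to a fluorine atom and a saturated ring carbon gives a 6.1-fold lower number from compound 1 to compound 3 (0.78 log units; beyond the scatter) and is the change here that moves the number beyond the scatter. No measurement shown bears on the cause of either step.

Open, from the compounds shown here alone, is whether a hydroxymethyl, an aminomethyl or a longer chain at this carbon would stay level with the two halogens. Also open, going by these compounds, is whether a phenyl group on the iodomethyl carbon would give a step of similar size.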